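Replacing aminomethyl with hydroxy: working notes on the series

The source may report more compounds than this note shows. Statements on the series, on what has been measured and on what is new or still open speak of the compounds shown alone.

In a functional assay on PC-6 cells (Homo sapiens) for cytotoxicity, read by MTT assay, with a stated time of 3 days (a lower number here means a stronger inhibitor, a higher number a weaker inhibitor), compound 1 (`CC(C)(C)c1cc2c(N/N=C/c3ccc(CN)cc3)ncnc2s1`) gives 0.214 ug/mL and lies within the scatter of compound 2 (`CC(C)N1Cc2ccc(/C=N/Nc3ncnc4sc(C(C)(C)C)cc34)cc2C1`) at 0.134 ug/mL but clearly above compound 3 (`CC(C)(C)c1cc2c(N/N=C/c3ccc4c(c3)CNC4)ncnc2s1`) at 0.071 ug/mL on these numbers. Compound 4 (`CC(C)(C)c1cc2c(N/N=C/c3ccc(O)cc3)ncnc2s1`) is still unmeasured. The change to it is hydroxy in place of aminomethyl on an aromatic carbon with hydroxy in place of aminomethyl on an aromatic carbon, para to a large group. Among the measured compounds shown here, the only measured step of a 1.9-fold lower number from compound 2 to compound 3 (0.28 log units; within the scatter) concerns an amine nitrogen in a ring and bears on this change only indirectly. For the measured compounds named here, all three measured compounds carry an amine nitrogen, compound 4 carries none, and no measured step removes one. Going by the values given here, the direction is therefore a cautious expectation, with no direct precedent behind it. The expected step is a 2.8-fold higher number from compound 1 to compound 4 (0.45 log units; beyond the scatter) in this assay and its size remains loosely set. The estimated value for compound 4 is 0.6 ug/mL within an expected range of 0.15 ug/mL to 2.5 ug/mL for now.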

Compound 4, half-maximal inhibitory concentration: > 10 ug/mL
Compound 4 ended at the assay's limit; the forecaster's own chance of this, stated with the estimate: 3%; middle value at least 16-fold (1.22 log units) away from the limit.
By their numbers in this assay, from the lowest: compounds 3, 2 and 1 (each within the scatter of the next, the first and the last beyond it). At a limit, above all of these: compound 4.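

In this assay, the change from 4-(aminomethyl)phenyl to 4-hydroxyphenyl, para to a large group, gives an at least 46-fold higher number from compound 1 to compound 4 (1.66 log units; beyond the scatter), the only step shown at this position, and it is large. Compound 4 stands at a limit of the assay, not at a number: the limit of > 10 ug/mL in this assay, at which 1 of the 4 values shown sits. The two groups have the same counts of hydrogen-bond donors and acceptors, so those counts do not separate compound 1 from compound 4, and among the compounds shown only compound 4 lacks an amine nitrogen.

The compounds shown leave open whether the step follows the nitrogen or the carbon link: hydroxymethyl here would keep the link without the nitrogen, and a plain amino group would keep the nitrogen without the link. As far as these compounds go, how a carboxylic acid or a longer amine chain would read at this position also stays open.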